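The compounds below may be only part of what the source reports. "The series", "measured", "known", "first", "only" and "open" are said of these compounds alone.

Measured compounds in a functional assay on SK-N-AS cells (Homo sapiens) for antiproliferative activity, with a stated time of 72 h; a lower number here means a stronger inhibitor, a higher number a weaker inhibitor:
compound 1, `CN(C)c1ccc(C(=O)N(CCC(=O)NCc2ccc(Cl)cc2)Cc2ccc(C(=O)NO)cc2)cc1`, gives 390 nM;
compound 2, `COc1cc(OC)cc(C(=O)N(CCC(=O)NCc2ccccc2)Cc2ccc(C(=O)NO)cc2)c1`, gives 9470 nM;
compound 3, `Cc1ccc(C(=O)N(CCC(=O)NCc2ccccc2)Cc2ccc(C(=O)NO)cc2)cc1`, gives 910 nM.

Compound 3 stands second highest of the three numbers in this assay. Among the compounds with values here, its nearest neighbour is compound 1, whose number is lower by a margin beyond the scatter; compound 2 is furthest, with a higher number, and the step of a 10-fold lower number from compound 2 to compound 3 (1.02 log units; beyond the scatter) is the only change of one place recorded among the measured compounds, and it is a large one.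

The compound not yet measured is compound 4, `CN(C)c1ccc(C(=O)N(CCC(=O)NCc2ccccc2)Cc2ccc(C(=O)NO)cc2)cc1`. It differs from compound 3 in one place: dimethylamino in place of methyl on an aromatic carbon. Within the data shown here, no measured step covers this exact exchange. The step of a 10-fold lower number from compound 2 to compound 3 (1.02 log units; beyond the scatter) shows that the group on the carbonyl carbon can move the number strongly, but it compares a different pair of groups. Compound 1 also carries the dimethylamino group, though its other end differs from compound 4 by a chlorine atom, so what those two values show is only indirect: compound 1 gives 390 nM, while compound 3 gives 910 nM.

Relative to compound 3, the number for compound 4 is expected to fall, by an estimated 1.7-fold lower number from compound 3 to compound 4 (0.22 log units; within the scatter). In this assay compound 4 is estimated at 550 nM, within a range from 220 nM to 1400 nM.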

Compound 4, half-maximal inhibitory concentration: 1420 nM
Compound 4: the middle estimate sits 2.6-fold (0.41 log units) below what was measured; measured number above the stated range.
By their numbers in this assay, from the lowest: compound 1; then compounds 3 and 4 (each within the scatter of the next); then compound 2.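

In (this assay), placing dimethylamino rather than methyl on this aromatic carbon gives (a 1.6-fold higher number from compound 3 to compound 4 (0.19 log units; within the scatter)), so the two groups cannot be told apart here, even though dimethylamino adds a nitrogen atom and a hydrogen-bond acceptor. Compound 4 also shows that the 4-(dimethylamino)phenyl group, like the 4-methylphenyl group of compound 3, stands clear of the 3,5-dimethoxyphenyl group of compound 2 (a 6.7-fold lower number from compound 2 to compound 4 (0.82 log units; beyond the scatter)). The pair that shares dimethylamino isolates a second site, with hydrogen in place of chloro at the far end of the molecule (a 3.6-fold higher number from compound 1 to compound 4 (0.56 log units; beyond the scatter)), so the lower number of compound 1 goes with its chlorine and not with dimethylamino.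

Nothing available explains why either exchange reads as it does. The compounds shown leave open whether chloro at that far end would act the same way alongside methyl, and how a primary amine, a methoxy group or a carboxylic acid would read on the aromatic carbon where methyl and dimethylamino sit.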